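The source may report more compounds than this note shows. Statements on the series, on what has been measured and on what is new or still open speak of the compounds shown alone.

Measured compounds:
- compound 1, `Cc1cccc(NC(=O)CN2CCN(c3cccc4ccccc34)CC2)c1`: 28.4 nM
- compound 2, `Cc1ccc(C2CCN(CC(=O)Nc3cccc(C)c3)CC2)nc1`: 41.7 nM

Both compounds were run in an assay on HEK293 cells for displacement of a labelled ligand from D(4) dopamine receptor (Homo sapiens), read by scintillation counting, with a stated time of 60 min; a lower number here means a stronger inhibitor, a higher number a weaker inhibitor. Compound 1 gives 28.4 nM and compound 2 gives 41.7 nM; the two numbers lie within the scatter of each other, so no order between them can be read from this pair. Compound 2 holds the higher of the two numbers, but only by a margin that repeated runs of this assay would routinely produce. The two structures also differ in more than one place, so nothing is set down as a step between them.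

Compound 3, `Cc1ccc(C2CCN(CC(=O)Nc3cccc(C)c3)CC2)cc1`, is the next compound for this assay. Relative to compound 2 the change is 4-methylphenyl in place of 5-methylpyridin-2-yl on a saturated ring carbon. The amide side of the molecule and the saturated ring itself are kept; only the aromatic group on the saturated ring carbon is exchanged.

Going by the values given here, no measured pair shows this particular exchange, so the expectation rests on compound 2 alone. The expected step is small, a 1.4-fold lower number from compound 2 to compound 3 (0.14 log units; within the scatter), in a direction not beyond the scatter. Compound 3 is estimated at 30 nM in this assay, with a range from 10 nM to 120 nM.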

Compound 3, inhibition constant: 110 nM
Estimate against measurement, compound 3: 3.7-fold (0.56 log units) below, within the range that was stated.
By their numbers in this assay, from the lowest: compounds 1 and 2 (each within the scatter of the next); then compound 3.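

In this assay the exchange of 5-methylpyridin-2-yl for 4-methylphenyl on the saturated ring carbon gives a 2.6-fold higher number from compound 2 to compound 3 (0.42 log units; beyond the scatter) and this modest step is the only one in the series that can be read. The two groups both have 7 heavy atoms and one six-membered aromatic ring, and the count differs in that the group leaving holds 1 nitrogen and 1 hydrogen-bond acceptor where the group entering holds neither. This position therefore responds to a change of aromatic group even when the heavy-atom count stays the same, but no measurement here accounts for the step.

A single pair cannot show whether the ring nitrogen alone carries the step, since the nitrogen and the aromatic group change together; a pyrimidin-2-yl group with a second ring nitrogen, or a pyridin-3-yl group with the nitrogen placed elsewhere in the ring, would bear on this. As far as these compounds go, whether the step persists with a different amide side also remains open, for example with an unsubstituted phenyl amide in place of the 3-methylphenyl amide.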